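From a Dimethylphenyl Amide to a Chlorophenyl Amide

This account rests on a few compounds, and the source may have more. Where it says the series, first, only, none or still open, it means among the compounds named here.

Compound 3 `Cc1ccc(C)c(NC(=O)c2ccc(/N=N\c3c[nH]c4ccccc34)cc2)c1` carries a 2,5-dimethylphenyl on its amide nitrogen. In a functional assay on P388 cells (Mus musculus) for inhibition, read by MTT assay, with a stated time of 72 h (a higher number here means a weaker inhibitor, a lower number a stronger inhibitor), compound 3 gives "not active" (no number reported), so no single number places it. Its companions offer little more: compound 1 `O=C(Nc1ccccc1[N+](=O)[O-])c1ccc(/N=N\c2c[nH]c3ccccc23)cc1` gives 77900 nM in this assay, and compound 2 `O=C(Nc1ccccc1Cl)c1ccc(/N=N\c2c[nH]c3ccccc23)cc1` gives "not active" (no number reported). Compound 4 `O=C(Nc1ccc(Cl)cc1)c1ccc(/N=N\c2c[nH]c3ccccc23)cc1` differs from compound 3 in one place: 4-chlorophenyl in place of 2,5-dimethylphenyl on an amide-type nitrogen. Within the data shown here, no step between measured compounds is available, and two of the three measured compounds return no number, so any shift for compound 4 in this assay cannot be sized; weak inhibition, or none, is what the set suggests. Compound 4 is therefore estimated at 80000 nM, with a range from 30000 nM to 200000 nM, and it may well return no number at all.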

Compound 4, half-maximal inhibitory concentration: 80000 nM
For compound 4 middle estimate and measured number coincide at the digits printed; low and high end bracket the measured number.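

With compound 4, a second group on the amide nitrogen returns a number in this assay: the step is a 1.0-fold higher number from compound 1 to compound 4 (0.01 log units; within the scatter) and 4-chlorophenyl cannot be told apart from 2-nitrophenyl at this position. Compound 3 returned no number while compound 4 did, so a change at this nitrogen alone separates a compound without a reading from one with a reading. No measurement shown explains why these groups read as they do.

From the compounds shown here alone, whether an amine or a carboxylic acid on the phenyl group, or a longer chain in its place, would give a much lower number remains open.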